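Aryl triazole variation on the urea series

The source may report more compounds than this note shows. Statements on the series, on what has been measured and on what is new or still open speak of the compounds shown alone.

Measured:
compound 1 `N#Cc1ccccc1-n1cc(COc2cccc(NC(=O)Nc3ccc(Cl)c(C(F)(F)F)c3)c2)nn1` — 1970 nM
compound 2 `CC(C)c1ccc(-n2cc(COc3cccc(NC(=O)Nc4ccc(Cl)c(C(F)(F)F)c4)c3)nn2)cc1` — 2470 nM

In a functional assay on HepG2 cells (Homo sapiens) for inhibition, read by MTT assay, with a stated time of 72 h (on this read-out lower numbers stand for stronger inhibition and higher numbers for weaker inhibition), compound 1 gives 1970 nM and compound 2 gives 2470 nM. Compound 2 holds the higher of the two numbers, but the step of a 1.3-fold higher number from compound 1 to compound 2 (0.10 log units; within the scatter) is within the scatter, so the two cannot be told apart on this read-out.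

Compound 3 `O=C(Nc1cccc(OCc2cn(-c3ccccc3F)nn2)c1)Nc1ccc(Cl)c(C(F)(F)F)c1` is not yet measured. It differs from compound 2 by 2-fluorophenyl in place of 4-isopropylphenyl on an aromatic nitrogen. Among the compounds with values here, the only step that bears on this position is the one from compound 1 to compound 2, exchanging one aryl group on the aromatic nitrogen for another, and that step was within the scatter. Nothing else on the aryl group has been varied, so the expected step of a 1.2-fold lower number from compound 2 to compound 3 (0.07 log units; within the scatter) is none beyond the scatter. For compound 3 the estimate in this assay is 2100 nM, with a range from 900 nM to 4800 nM.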

Compound 3, half-maximal inhibitory concentration: 1520 nM
Beside the measured number, compound 3's estimate is 1.4-fold (0.14 log units) above it, and the stated range covers the measured number.
By their numbers in this assay, from the lowest: compounds 3, 1 and 2 (each within the scatter of the next).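

In this assay, both new steps stay within the scatter: a 1.6-fold lower number from compound 2 to compound 3 (0.21 log units; within the scatter) for 2-fluorophenyl in place of 4-isopropylphenyl, and a 1.3-fold lower number from compound 1 to compound 3 (0.11 log units; within the scatter) for fluoro in place of cyano on an aromatic carbon. Three different aryl groups on the aromatic nitrogen now cannot be told apart on this read-out, and the direct exchange of cyano for fluoro adds a comparison the first pair did not offer. No data at hand bear on the reason for this result.

Open, going by these compounds, is whether any group at this position moves the number beyond the scatter, for example an aryl ring carrying an amine or a carboxylic acid, or a longer alkyl chain in place of the aryl ring. Also open, on these data alone, is whether the absence of a readable step extends to changes elsewhere on the shared core.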